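A Nitro Group Replaces Chloro at the Assay Limit

This account rests on a few compounds, and the source may have more. Where it says the series, first, only, none or still open, it means among the compounds named here.

The compounds are read in a functional assay on NCI-H460 cells (Homo sapiens) for cytotoxicity, read by MTT assay, with a stated time of 48 h; a higher number here means a weaker inhibitor, a lower number a stronger inhibitor. Compound 1 `O=c1[nH]c2ccccc2cc1-c1nc2cc([N+](=O)[O-])ccc2[nH]1` gives only a limit in this assay, namely > 100000 nM. Compound 2 `COc1ccc2[nH]c(=O)c(-c3nc4cc(Cl)ccc4[nH]3)cc2c1` likewise gives only a limit in this assay, namely > 100000 nM. Compound 2 thus stands at the limit of this assay, where both of the values shown sit (the limit of > 100000 nM in this assay, at which 2 of the 2 values shown sit). For the measured compounds named here, no step between measured compounds is therefore available, and no number separates compound 2 from compound 1. Compound 3 `COc1ccc2[nH]c(=O)c(-c3nc4cc([N+](=O)[O-])ccc4[nH]3)cc2c1` differs from compound 2 in one place: nitro in place of chloro on an aromatic carbon. Compound 1 carries the same nitro group on an aromatic carbon and also sits at the limit. From compound 2 to compound 3, no step beyond the scatter is expected, the estimated step being a step that the limit leaves unreadable from compound 2 to compound 3. Compound 3 is expected to give about 150000 nM in this assay, within a range from 50000 nM to 500000 nM, most likely again reported only as a limit.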

Compound 3, half-maximal inhibitory concentration: > 100000 nM
Compound 3: no number, only a limit (the forecaster's own chance of this, stated with the estimate: 85%); the middle value is on the limit's open side.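

Compound 3, like compound 1 and compound 2, gives only a limit in this assay, so the steps to compound 3 from compound 2 and from compound 1 cannot be read: the limit of > 100000 nM in this assay, at which 3 of the 3 values shown sit.

Going by these compounds, whether nitro in place of chloro, or methoxy in place of hydrogen, changes the read-out at all remains open.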